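A few compounds are considered here, and "the series" means these few. Any claim that something is new, unique, unknown or untested is made for them only; others in the source may bear on it.

Compound 1 `COc1ccccc1-c1ncnc2c1ncn2C[C@@H]1C[C@H](O)c2ccccc21` gives > 200000 nM in an ADME assay on L1210/0 cells (Mus musculus) for cytotoxicity, with a stated time of 48 h (on this read-out lower numbers stand for stronger inhibition and higher numbers for weaker inhibition), which is a limit of the assay, and its different structure gives it no bearing here. Compound 2 `CC1(C)[C@@H](Cn2cnc3c(Cl)nc(N)nc32)CC[C@@]1(C)CO` reads 50000 nM. Compound 3 `CC1(C)[C@@H](Cn2cnc3c(O)nc(N)nc32)CC[C@@]1(C)CO` reads > 200000 nM, also only a limit. Compound 4 `CC1(C)[C@@H](Cn2cnc3c(N)nc(N)nc32)CC[C@@]1(C)CO` carries amino in place of hydroxy on an aromatic carbon. Within the data shown here, the one measured step at that carbon is an at least 4.0-fold higher number from compound 2 to compound 3 (0.60 log units; beyond the scatter), where hydroxy replaced chloro. Removing the hydroxy may therefore move the reading back towards compound 2 at 50000 nM. A limit remains possible for compound 4. The expected change is an at least 2.0-fold lower number from compound 3 to compound 4 (0.30 log units; that floor lies within the scatter), modest and towards lower numbers. For compound 4 the estimate is 100000 nM, with an expected range of 30000 nM to 200000 nM.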

Compound 4, half-maximal inhibitory concentration: > 200000 nM
Compound 4: a limit, no number; the forecaster's own chance of this, stated with the estimate: 35%; at least 2.0-fold (0.30 log units) between middle value and limit.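

Amino in place of chloro gives an at least 4.0-fold higher number from compound 2 to compound 4 (0.60 log units; beyond the scatter), the same direction as the step with hydroxy, so among these three groups at this aromatic carbon only chloro gives a reading short of the limit. The step from compound 3 to compound 4 cannot be read, because both compounds stand at a limit: the limit of > 200000 nM in this assay, at which 3 of the 4 values shown sit.

Amino and hydroxy therefore remain unordered. Still open, as far as these compounds go, is whether another group on this carbon, such as bromo or a thiol, would give a reading like that of compound 2 or a lower one.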